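The source may report more compounds than this note shows. Statements on the series, on what has been measured and on what is new or still open speak of the compounds shown alone.

Notes on the series. Compound 2 `Cc1cc(NC(=O)Cn2nnc(-c3ccccn3)n2)n(C2CCCCC2)n1` stands at the high end of the two measured compounds in an assay on HEK293 cells for activation of Kir3.1/Kir3.2 (Homo sapiens), read by thallium flux (a higher number here means that more compound is needed for the effect, a lower number that less compound is needed), where compound 2 gives 14600 nM. Within the data shown here, compound 1 `O=C(Cn1nnc(-c2ccccc2)n1)Nc1cc(C2CC2)nn1C1CCCCC1` gives 271 nM in this assay; it differs from compound 2 in two places, phenyl rather than pyridin-2-yl and cyclopropyl rather than methyl, so no single step between the two can be isolated. Compound 3 `Cc1cc(NC(=O)Cn2nnc(-c3ccc(F)c(F)c3)n2)n(C2CCCCC2)n1` has not yet been measured. The change from compound 2 to compound 3 is 3,4-difluorophenyl in place of pyridin-2-yl on an aromatic carbon. With the methyl of compound 2 retained, compound 3 brings in a carbon-only aromatic ring of the kind compound 1 also carries. A move toward lower numbers is expected, beyond the scatter, though how much of the gap between compound 2 and compound 1 belongs to the cyclopropyl-for-methyl part cannot be told from these two values. The expected step from compound 2 to compound 3 in this assay is a 9.7-fold lower number from compound 2 to compound 3 (0.99 log units; beyond the scatter). Compound 3 is estimated at 1500 nM, with a range from 300 nM to 8000 nM, because compound 1 with its carbon-only ring gives 271 nM.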

Compound 3, half-maximal effective concentration: 116 nM
Beside the measured number, compound 3's estimate is 13-fold (1.11 log units) above it, outside the stated range (below it).
By their numbers in this assay, from the lowest: compound 3; then compound 1; then compound 2.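

In this assay, this position on the five-membered aromatic ring with 4 nitrogen is now seen in a single-place change: with the methyl retained, 3,4-difluorophenyl in place of pyridin-2-yl gives a 130-fold lower number from compound 2 to compound 3 (2.10 log units; beyond the scatter). This one change removes the ring nitrogen and brings in 2 fluorine atoms together, so the step cannot be divided between the two.

Among these compounds, compound 1 differs from compound 2 and from compound 3 in two places, so no step to it can be read, and it remains open whether cyclopropyl in place of methyl would change the value of compound 3, or how a plain phenyl, a 4-fluorophenyl or a 4-methoxyphenyl would compare at this position. What lies behind the step also remains open, with no measurement available that bears on its cause.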